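A few compounds are considered here, and "the series" means these few. Any claim that something is new, unique, unknown or untested is made for them only; others in the source may bear on it.

- compound 1 `CC(C)c1n[nH]c2c(NCc3ccc(-c4ccccn4)cc3)nc(SCC3CNC(=O)O3)nc12`: 80 nM
- compound 2 `CSc1nc(NCc2ccc(-c3ccccn3)cc2)c2[nH]nc(C(C)C)c2n1`: 783 nM

Both numbers come from a functional assay on HT cells (Homo sapiens) for antiproliferative activity, read by fluorescence, with a stated time of 72 h; a higher number here means a weaker inhibitor of growth, a lower number a stronger inhibitor of growth. Compound 2 holds the higher of the two numbers, so it is the weaker inhibitor of growth of this pair. The next compound, compound 3 `CC(C)c1n[nH]c2c(NCc3ccc(-c4ccccn4)cc3)nc(SC(C)C(C)O)nc12`, carries 2-hydroxy-1-methylpropyl in place of methyl on a sulfur.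

Among the measured compounds shown here, only one measured step bears on this change. It is a 9.8-fold higher number from compound 1 to compound 2 (0.99 log units; beyond the scatter), and it also alters the group on the sulfur, with hydrogen in place of 2-oxo-1,3-oxazolidin-5-yl on a saturated chain carbon bound to a sulfur. Read in reverse, it links the longer group of compound 1 to the lower number, 80 nM. For the measured compounds named here, this is a single pair and no pattern, and no measured compound carries the 2-hydroxy-1-methylpropyl group. A fall is therefore expected, somewhat smaller than the measured step and with wide uncertainty. The estimated step is a 5.2-fold lower number from compound 2 to compound 3 (0.72 log units; beyond the scatter). For compound 3 the expected value is 150 nM, with an estimated range from 40 nM to 550 nM.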

Compound 3, concentration for 50% growth inhibition: 190 nM
Compound 3: the middle estimate sits 1.3-fold (0.10 log units) below what was measured, within the range that was stated.
By their numbers in this assay, from the lowest: compound 1; then compound 3; then compound 2.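

Putting 2-hydroxy-1-methylpropyl in place of methyl on a sulfur gives a 4.1-fold lower number from compound 2 to compound 3 (0.62 log units; beyond the scatter) in this assay, so a group without a ring also goes with a lower number at this position, and the earlier fall is not tied to the 2-oxo-1,3-oxazolidin-5-yl ring alone. The ring still matters in this comparison: replacing (2-oxo-1,3-oxazolidin-5-yl)methyl with 2-hydroxy-1-methylpropyl gives a 2.4-fold higher number from compound 1 to compound 3 (0.38 log units; beyond the scatter), so the two larger groups on this sulfur are not equivalent, though both stand below methyl in number. No measurement of any property of these groups accompanies the result, and the reason for either step stays unknown.

Both larger groups carry oxygen, so the compounds shown do not tell whether the oxygen or the added carbon goes with the lower numbers, and a plain butyl chain on the same sulfur would separate the two. From the compounds shown here alone, it also remains open how an amine or a carboxylic acid in place of the hydroxyl of 2-hydroxy-1-methylpropyl would stand against these values.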